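Para substituent swap on the phenylpropanamide side chain

The source may report more compounds than this note shows. Statements on the series, on what has been measured and on what is new or still open speak of the compounds shown alone.

Of the compounds shown here, three sharing one core have been measured in a functional assay on HEK293 cells for antagonist activity at P2X purinoceptor 7 (Homo sapiens), read by fluorescence, with a stated time of 2 h; on this read-out higher numbers stand for weaker inhibition and lower numbers for stronger inhibition. Compound 1 `O=C(CCc1ccccc1)NNc1c(Cl)cncc1Cl` gives 650 nM. Compound 2 `O=C(CCc1ccc(F)cc1)NNc1c(Cl)cncc1Cl` gives 900 nM. Compound 3 `O=C(CCc1ccc(Cl)cc1)NNc1c(Cl)cncc1Cl` gives 1100 nM. All three numbers lie within the scatter of one another, so compound 3 cannot be set apart from compound 1 or compound 2 on these data.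

Compound 4 `Cc1ccc(CCC(=O)NNc2c(Cl)cncc2Cl)cc1` differs from compound 3 by methyl in place of chloro on an aromatic carbon. Going by the values given here, no measured step introduces a methyl, so the nearest guides are the steps that vary the same aromatic position: a 1.7-fold higher number from compound 1 to compound 3 (0.23 log units; within the scatter), a 1.4-fold higher number from compound 1 to compound 2 (0.14 log units; within the scatter) and a 1.2-fold higher number from compound 2 to compound 3 (0.09 log units; within the scatter). None of these moved the number beyond the scatter. The step to compound 4 is therefore expected to be of similar size, with no direction that can be read from the three measured compounds.

Compound 4 is expected to give about 900 nM in this assay, with a likely range from 450 nM to 1800 nM, which corresponds to an expected step of a 1.2-fold lower number from compound 3 to compound 4 (0.09 log units; within the scatter).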

Compound 4, half-maximal inhibitory concentration: 1400 nM
Estimate against measurement, compound 4: 1.6-fold (0.19 log units) below, and the stated range covers the measured number.
By their numbers in this assay, from the lowest: compounds 1, 2, 3 and 4 (each within the scatter of the next, the first and the last beyond it).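

In this assay, going by these compounds alone, methyl on the aromatic carbon para to a large group gives the first step from the unsubstituted compound that lies beyond the scatter, though only modestly (a 2.2-fold higher number from compound 1 to compound 4 (0.33 log units; beyond the scatter)). Methyl cannot be separated from either halogen at this place, as both steps stay within the scatter (a 1.3-fold higher number from compound 3 to compound 4 (0.10 log units; within the scatter); a 1.6-fold higher number from compound 2 to compound 4 (0.19 log units; within the scatter)), so only the comparison with hydrogen is resolved. No evidence on hand bears on the reason for this step.

From the compounds shown here alone, all four compounds carry hydrogen or a small single substituent at this place, so it remains open whether an amine, a carboxylic acid or a methoxy group there would give a lower number than compound 1 does. Going by these compounds, the effect of a shorter or longer chain between the aromatic ring and the carbonyl also remains open.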